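A few compounds are considered here, and "the series" means these few. Any claim that something is new, unique, unknown or untested is made for them only; others in the source may bear on it.

Working notes on the series. Compound 1 `O=C(/C=C/c1ccc(Br)cc1)Nc1ccc2ncnc(Nc3cccc(Br)c3)c2c1` gives 15.3 ug/mL in a functional assay on A549 cells (Homo sapiens) for antiproliferative activity, read by MTT assay, with a stated time of 48 h (a lower number here means a stronger inhibitor, a higher number a weaker inhibitor), the highest of the two numbers in hand. Compound 2 `Cc1ccc(/C=C/C(=O)Nc2ccc3ncnc(Nc4cccc(Br)c4)c3c2)cc1` gives 3.01 ug/mL in this assay. Within the data shown here, the single measured step at this position, a 5.1-fold lower number from compound 1 to compound 2 (0.71 log units; beyond the scatter), shows that exchanging the group on that ring shifts the read-out beyond the scatter. Compound 3 `O=C(/C=C/c1ccc([N+](=O)[O-])cc1)Nc1ccc2ncnc(Nc3cccc(Br)c3)c2c1` differs from compound 1 by nitro in place of bromo on an aromatic carbon. Among the measured compounds shown here, no measured pair sets bromo against nitro, so the direction rests on the methyl exchange alone, which points to a lower number. For compound 3 the expected step is a 1.9-fold lower number from compound 1 to compound 3 (0.28 log units; within the scatter). The estimate for compound 3 is 8 ug/mL, with a range from 3 ug/mL to 25 ug/mL.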

Compound 3, half-maximal inhibitory concentration: 1.85 ug/mL
Beside the measured number, compound 3's estimate is 4.3-fold (0.64 log units) above it; measured number below the stated range.
By their numbers in this assay, from the lowest: compounds 3 and 2 (each within the scatter of the next); then compound 1.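

Nitro in place of bromo on this ring gives a step beyond the scatter (an 8.3-fold lower number from compound 1 to compound 3 (0.92 log units; beyond the scatter)), so in this assay the lower number is not confined to the methyl exchange: both replacements of the 4-bromophenyl group lower it. Nitro and methyl are not separated at this position (a 1.6-fold lower number from compound 2 to compound 3 (0.21 log units; within the scatter)). No measurement on these groups is at hand to explain the result. Open, from the compounds shown here alone, is whether an amine, a carboxylic acid or a longer chain in the same place would give a number like those of compound 2 and compound 3.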